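Swapping a trifluorophenyl group for a benzyl group

The source may report more compounds than this note shows. Statements on the series, on what has been measured and on what is new or still open speak of the compounds shown alone.

Compound 1 `O=C(O)c1cn(C2CC2)c2cc(N3CCN(C(=O)CCSc4nnnn4-c4ccc(Br)cc4)CC3)c(F)cc2c1=O` gives 60 nM
Compound 2 `CCn1cc(C(=O)O)c(=O)c2cnc(N3CCN(C(=O)CCSc4nnnn4-c4ccc(F)c(F)c4F)CC3)nc21` gives 60 nM

In a functional assay on SiHa cells (Homo sapiens) for inhibition, read by sulforhodamine B assay, with a stated time of 48 h (a lower number here means a stronger inhibitor of growth, a higher number a weaker inhibitor of growth), compound 2 gives 60 nM and stands level with compound 1 at 60 nM within the usual scatter. Compound 3 `CCn1cc(C(=O)O)c(=O)c2cnc(N3CCN(C(=O)CCSc4nnnn4Cc4ccccc4)CC3)nc21` carries benzyl in place of 2,3,4-trifluorophenyl on an aromatic nitrogen of a five-membered aromatic ring with 4 nitrogen. Going by the values given here, no measured pair shows this swap alone, so the guide is thin. A small weakening in this assay is expected, and the estimated 1.7-fold higher number from compound 2 to compound 3 (0.22 log units; within the scatter) may well stay within the scatter. For compound 3 the expected value is 100 nM with an estimated range of 30 nM to 350 nM in this measurement.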

Compound 3, concentration for 50% growth inhibition: 60 nM
The estimate for compound 3 lay 1.7-fold (0.22 log units) above the measured number, and the stated range covers the measured number.
By their numbers in this assay, from the lowest: compounds 1, 2 and 3 (each within the scatter of the next).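

In this assay the swap of 2,3,4-trifluorophenyl for benzyl on this aromatic nitrogen of the five-membered aromatic ring with 4 nitrogen gives no change at the digits printed from compound 2 to compound 3 (within the scatter). On this core, then, the position holds its level in growth inhibition with either group, so the three fluorine atoms of compound 2 are not needed here. Nothing measured here explains this result.

Still open, on these data alone, is whether a group without an aromatic ring, such as an ethyl chain, would hold the same level at this nitrogen. A benzyl group carrying an amine or a carboxylic acid also remains untested in the compounds shown here.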